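This account rests on a few compounds, and the source may have more. Where it says the series, first, only, none or still open, it means among the compounds named here.

Compound 1 `O=C(CCCCCCc1ccccc1)c1nc(-c2cccs2)no1`: in an assay on HEK-293T cells for inhibition of diacylglycerol lipase-alpha (Homo sapiens), read by colorimetric assay (on this read-out higher numbers stand for weaker inhibition and lower numbers for stronger inhibition), compound 1 gives 1950 nM.
Compound 2 `COC(=O)c1cccc(-c2noc(C(=O)CCCCCCc3ccccc3)n2)n1`: in this assay compound 2 reaches only a limit, > 10000 nM.

Compound 2 therefore stands at the limit of > 10000 nM in this assay, at which 1 of the 2 values shown sits, and no number for it is known. Compound 3 `O=C(CCCCCCc1ccccc1)c1nc(-c2cccc(Cl)n2)no1` differs from compound 2 by chloro in place of methoxycarbonyl on an aromatic carbon. No step between measured compounds is shown, so the size of this change cannot be read from a neighbouring pair. The expected step is an at least 2.0-fold lower number from compound 2 to compound 3 (0.30 log units; that floor lies within the scatter), a move out of the limit into the measurable range. For compound 3 in this assay the estimate is 5000 nM, with a range from 1500 nM to 20000 nM.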

Compound 3, half-maximal inhibitory concentration: > 10000 nM
Compound 3 gave a limit, no number; the forecaster's own chance of this, stated with the estimate: 40%; middle value at least 2.0-fold (0.30 log units) from the limit.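

Compound 3 also gives only a limit in this assay, > 10000 nM, so chloro in place of methoxycarbonyl yields no readable step and no measurable value at this position: the limit of > 10000 nM in this assay, at which 2 of the 3 values shown sit. The new information comes from the other comparison: 6-chloropyridin-2-yl in place of thiophen-2-yl gives an at least 5.1-fold higher number from compound 1 to compound 3 (0.70 log units; beyond the scatter), so inhibition is clearly weaker with this chloro-bearing ring.

On these data alone, how far the true values of compound 2 and compound 3 lie past the limit remains open. Also open, as far as these compounds go, is whether an amine or a methyl group at this position would bring a measurable value.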